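The source may hold more compounds than are shown below. What is called first, only, known or untested is meant among the compounds shown, and "the series" means these compounds.

Measured in a functional assay on ECa-109 cells (Homo sapiens) for antiproliferative activity, read by MTT assay, with a stated time of 72 h; a lower number here means a stronger inhibitor, a higher number a weaker inhibitor:
Compound 1 `CCCSc1nc(N/N=C/c2ccc(Cl)cc2)c2nnn(Cc3ccccc3)c2n1` gives only a limit, > 64000 nM.
Compound 2 `CCCSc1nc(N/N=C/c2ccc3ccccc3c2)c2nnn(Cc3ccccc3)c2n1` gives only a limit, > 64000 nM.
Compound 3 `CCCSc1nc(N/N=C/c2c[nH]c3ccccc23)c2nnn(Cc3ccccc3)c2n1` gives 8690 nM.

Compound 1 thus sits at the limit of > 64000 nM in this assay, at which 2 of the 3 values shown sit, so no number is known for it. Compound 4 `CCCSc1nc(N/N=C(\C)c2ccccc2)c2nnn(Cc3ccccc3)c2n1` differs from it by a group of 9 heavy atoms (8 carbon, 1 nitrogen; one six-membered aromatic ring of carbon only) in place of a group of 9 heavy atoms (7 carbon, 1 nitrogen, 1 chlorine; one six-membered aromatic ring of carbon only), on a nitrogen on an aromatic ring. For the measured compounds named here, no measured step makes this change. The change from compound 1 to compound 2 gives a step that the two limits leave unreadable from compound 1 to compound 2, and only the indole brings a number: an at least 7.3-fold lower number from compound 1 to compound 3 (0.86 log units; beyond the scatter) and an at least 7.3-fold lower number from compound 2 to compound 3 (0.86 log units; beyond the scatter). Compound 4 keeps a plain carbocyclic six-membered ring, like compound 1 and compound 2, so the expectation is that it stays at or near the limit and a step that the limit leaves unreadable from compound 1 to compound 4 remains unreadable. Compound 4 is estimated at 70000 nM, with a range from 20000 nM to 250000 nM.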

Compound 4, half-maximal inhibitory concentration: 32200 nM
For compound 4 the middle estimate is 2.2-fold (0.34 log units) above the measured one, and the stated range covers the measured number.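

In this assay, a group with one six-membered aromatic ring of carbon only, on a nitrogen on an aromatic ring, now gives a readable number, so the indole of compound 3 is not alone in doing so. As far as these compounds go, the change brings an at least 1.9-fold lower number from compound 1 to compound 4 (0.29 log units; that floor lies within the scatter), and its true size stays unknown. Compound 1 remains a limit: the limit of > 64000 nM in this assay, at which 2 of the 4 values shown sit.

The compounds shown do not separate the loss of the chlorine from the gain of the methyl. From the compounds shown here alone, what an amine or a carboxylic acid on that six-membered ring would give also stays open.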